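A few compounds are considered here, and "the series" means these few. Any claim that something is new, unique, unknown or untested is made for them only; others in the source may bear on it.

Working notes on the series. In a functional assay for inhibition, read by fluorescence and spectrophotometry, with a stated time of 30 h (a lower number here means a stronger inhibitor, a higher number a weaker inhibitor), compound 1 `COc1ccc(-c2cc(=O)c3ccc(OCCCN4CCC(CCO)CC4)cc3o2)cc1` gives 43200 nM while compound 2 `COc1ccc(-c2cc(=O)c3ccc(OCCCCCN4CCC(C)CC4)cc3o2)cc1` gives 55100 nM and compound 3 `COc1ccc(-c2cc(=O)c3ccc(OCCCCCCN4CCC(C)CC4)cc3o2)cc1` gives 57200 nM so all three values lie within the scatter of one another, and nothing separates compound 3 from the other two.

The next member is compound 4 `COc1ccc(-c2cc(=O)c3ccc(OCCCCCCCN4CCC(C)CC4)cc3o2)cc1` and the change from compound 3 is (4-methylpiperidin-1-yl)methyl in place of 4-methylpiperidin-1-yl on a saturated chain carbon, six bonds along the chain from an oxygen on an aromatic ring with (4-methylpiperidin-1-yl)methyl in place of 4-methylpiperidin-1-yl on a saturated chain carbon, six bonds along the chain from an oxygen on an aromatic ring.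

The closest measured precedent is the same replacement made five bonds along the chain, which is a 1.0-fold higher number from compound 2 to compound 3 (0.02 log units; within the scatter) and stays within the scatter. The steps of a 1.3-fold higher number from compound 1 to compound 2 (0.11 log units; within the scatter) and a 1.3-fold higher number from compound 1 to compound 3 (0.12 log units; within the scatter) replace 4-(2-hydroxyethyl)piperidin-1-yl with longer groups and also stay within the scatter. No step beyond the scatter is expected in this assay because a 1.0-fold higher number from compound 2 to compound 3 (0.02 log units; within the scatter) is the only measured case of this exact replacement. That is a single precedent, and no direction can be drawn from it.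

The expected step is a 1.0-fold lower number from compound 3 to compound 4 (0.00 log units; within the scatter) with no direction implied. For compound 4 the estimated value is 57000 nM with an expected range of 29000 nM to 105000 nM around it.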

Compound 4, half-maximal inhibitory concentration: 61600 nM
Compound 4: middle estimate off by 1.1-fold (0.03 log units), on the low side; the measured number falls inside the stated range.
By their numbers in this assay, from the lowest: compounds 1, 2, 3 and 4 (each within the scatter of the next).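

With (4-methylpiperidin-1-yl)methyl in place of 4-methylpiperidin-1-yl, six bonds along the chain from an oxygen on an aromatic ring, this assay gives a 1.1-fold higher number from compound 3 to compound 4 (0.03 log units; within the scatter), so this replacement now has a second case, one bond further along the chain than the first, and it again stays within the scatter. Among these compounds, the wider replacements agree: 2-(4-methylpiperidin-1-yl)ethyl in place of 4-methylpiperidin-1-yl gives a 1.1-fold higher number from compound 2 to compound 4 (0.05 log units; within the scatter), and 4-(4-methylpiperidin-1-yl)butyl in place of 4-(2-hydroxyethyl)piperidin-1-yl gives a 1.4-fold higher number from compound 1 to compound 4 (0.15 log units; within the scatter), so even these larger changes separate no compound. No supporting data bear on this result.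

The step from compound 1 changes the chain length and the group on the piperidine together, so their separate contributions remain unresolved. Also open, going by these compounds, is whether a longer chain than that of compound 4, or a morpholine or a dimethylamine in place of the 4-methylpiperidine, would produce a step beyond the scatter in this assay.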